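The source may hold more compounds than are shown below. What is called first, only, known or untested is meant among the compounds shown, and "the series" means these compounds.

Three compounds have been measured in an assay on CHO cells for displacement of a labelled ligand from adenosine receptor A3 (Homo sapiens), read by scintillation counting, tested at 10 uM; a higher number here means more inhibition at the concentration tested (going by the name of the read-out), a lower number less inhibition:

Compound 1, `CC(C)(C)Cc1c(-c2cccc(F)c2F)sc(N)c1C(=O)c1ccc(Cl)cc1`, gives 1%.
Compound 2, `CC(C)(C)Cc1c(-c2ccc(F)cc2F)sc(N)c1C(=O)c1ccc(Cl)cc1`, gives 1%.
Compound 3, `COc1cccc(-c2sc(N)c(C(=O)c3ccc(Cl)cc3)c2CC(C)(C)C)c1`, gives 1%.

Compound 3 stands level with both of the others: the step of no change at the digits printed from compound 1 to compound 3 (within the scatter) and the step of no change at the digits printed from compound 2 to compound 3 (within the scatter) are each within the scatter, as is the step of no change at the digits printed from compound 1 to compound 2 (within the scatter) between the two difluorophenyl analogues. All three compounds share one core and vary only in the aryl group on the thiophene carbon, and none of these variations moves the read-out out of the scatter.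

Compound 4, `Cc1cccc(-c2sc(N)c(C(=O)c3ccc(Cl)cc3)c2CC(C)(C)C)c1`, continues this series with the change (methyl in place of methoxy on an aromatic carbon). Going by the values given here, no measured step replaces a methoxy group with a methyl group, so the nearest guidance is the three steps among compounds 1, 2 and 3, every one of which is flat. With the aryl substituent already varied in each of those steps without effect, the step from compound 3 to compound 4 is expected to be a number 1 percentage points higher from compound 3 to compound 4 (within the scatter), that is, nothing beyond the scatter. Compound 4 is therefore estimated at 2%, within a range from -6% to 12%.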

Compound 4, a percentage reported as inhibition, at one concentration (the size of the read-out at that concentration, not a potency): 1%
Beside the measured number, compound 4's estimate is 1 percentage points above it; the range from low to high includes it.
By their numbers in this assay, from the lowest: compounds 1, 2, 3 and 4 (each within the scatter of the next).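

In this assay, methyl in place of methoxy on an aromatic carbon gives no change at the digits printed from compound 3 to compound 4 (within the scatter), so removing the oxygen and its hydrogen-bond acceptor from this position leaves the read-out flat. The earlier steps shown here had exchanged whole aryl groups, whereas this one alters a single substituent, and the 3-methylphenyl group also sits level with both difluorophenyl analogues, with no change at the digits printed from compound 2 to compound 4 (within the scatter) and no change at the digits printed from compound 1 to compound 4 (within the scatter). No evidence bears on why the read-out stays flat at this position.

The compounds shown leave open whether any group at this position can raise the read-out, such as an amine, a carboxylic acid or a longer chain in place of the methyl. They also leave open whether changes elsewhere on the shared core would matter, as only the aryl group varies here.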